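Swapping Cyclobutyl for tert-Butyl on Two Related Cores

The source may hold more compounds than are shown below. What is called first, only, known or untested is meant among the compounds shown, and "the series" means these compounds.

Compound 1 `CS(=O)(=O)c1ccc(-n2nc(C(F)(F)F)cc2OCC2CCC2)nc1` and compound 2 `CS(=O)(=O)c1ccc(-n2nc(C(F)(F)F)cc2OCC2CCC2)cc1` carry the same side chain but differ in their cores; the difference between the two cores is not broken down here. In a physicochemical assay for solubility (on this read-out lower numbers stand for lower solubility and higher numbers for higher solubility), compound 1 gives 100 ug/mL, while compound 2 gives 25 ug/mL, the lowest of the three measured numbers. Compound 3 `CC(C)(C)COc1cc(C(F)(F)F)nn1-c1ccc(S(C)(=O)=O)cn1` differs from compound 1 by the change (tert-butyl in place of cyclobutyl on a saturated chain carbon bound to an oxygen on an aromatic ring), and in this assay compound 3 gives 100 ug/mL, so the step of no change at the digits printed from compound 1 to compound 3 (within the scatter) is flat. Compound 4 `CC(C)(C)COc1cc(C(F)(F)F)nn1-c1ccc(S(C)(=O)=O)cc1` is built from compound 2 by the same change, (tert-butyl in place of cyclobutyl on a saturated chain carbon bound to an oxygen on an aromatic ring), applied to the core of compound 2. Because the step of no change at the digits printed from compound 1 to compound 3 (within the scatter) stayed within the scatter, compound 4 is expected to sit close to compound 2, with an expected step of no change at the digits printed from compound 2 to compound 4 (within the scatter) in this assay. Within the data shown here, only one earlier instance of this change has been measured, so the expectation rests on a single pair of compounds. The estimate for compound 4 in this assay is 25 ug/mL, expected to fall between 12 ug/mL and 50 ug/mL.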

Compound 4, solubility: 50 ug/mL
Compound 4: the middle estimate sits 2.0-fold (0.30 log units) below what was measured; the measured number falls inside the stated range.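

In this assay, among these compounds, carrying tert-butyl in place of cyclobutyl onto the second core gives a 2.0-fold higher number from compound 2 to compound 4 (0.30 log units; within the scatter), and the same change on the first core gave no change at the digits printed from compound 1 to compound 3 (within the scatter), so on both cores the step stays within the scatter. This shows only that, across these two pairs of compounds, the change carried over from one core to the other without a step beyond the scatter; two pairs do not establish a rule for the series, and the printed numbers alone cannot separate a small real rise from compound 2 to compound 4 from repeat-measurement noise. No evidence is available on why the change behaves this way on either core.

The compounds shown leave open whether a side chain ending in an amine or a carboxylic acid, in place of tert-butyl or cyclobutyl, would also stay within the scatter on these cores. They also leave open whether a longer chain at the same place would do so.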